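One ring swap, judged from a single prior step

A few compounds are considered here, and "the series" means these few. Any claim that something is new, unique, unknown or untested is made for them only; others in the source may bear on it.

Compound 1 `CNC(=O)c1cc(Oc2ccc(NC(=O)c3nn(-c4ccc(Br)cc4F)c(=O)cc3C)cc2F)ccn1` carries a 4-bromo-2-fluorophenyl group on an aromatic nitrogen of its shared core. Within the data shown here, in a functional assay on A549 cells (Homo sapiens) for cytotoxicity, read by MTT assay, with a stated time of 72 h (a higher number here means a weaker inhibitor, a lower number a stronger inhibitor), compound 1 gives 7930 nM, one of only two numbers recorded so far, and the other lies within the scatter of it: compound 2 `CNC(=O)c1cc(Oc2ccc(NC(=O)c3nn(-c4cccc(F)c4)c(=O)cc3C)cc2F)ccn1` in this assay gives 9540 nM. The step of a 1.2-fold higher number from compound 1 to compound 2 (0.08 log units; within the scatter) shows that exchanging this whole aryl group once before stayed within the scatter. Compound 3 `CNC(=O)c1cc(Oc2ccc(NC(=O)c3nn(-c4ccc(C)cc4)c(=O)cc3C)cc2F)ccn1` differs from compound 1 in that (4-methylphenyl in place of 4-bromo-2-fluorophenyl on an aromatic nitrogen). The step from compound 1 to compound 2 is the only measured one that bears on this change, and since it stayed within the scatter, a further exchange at the same position is expected to move the number by no more than the scatter, in no clear direction. Compound 3 is therefore estimated to give 9000 nM in this assay, with a likely range from 4000 nM to 20000 nM. The expected step is a 1.1-fold higher number from compound 1 to compound 3 (0.05 log units; within the scatter).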

Compound 3, half-maximal inhibitory concentration: 11500 nM
For compound 3 the middle estimate is 1.3-fold (0.11 log units) below the measured one; measured number inside the range.
By their numbers in this assay, from the lowest: compounds 1, 2 and 3 (each within the scatter of the next).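

In this assay, the exchange that removes both the bromine and the fluorine and leaves a 4-methylphenyl group gives a 1.5-fold higher number from compound 1 to compound 3 (0.16 log units; within the scatter), so a phenyl ring bearing no halogen is not separated from the 4-bromo-2-fluorophenyl group. Set against the 3-fluorophenyl group, the same 4-methylphenyl group gives a 1.2-fold higher number from compound 2 to compound 3 (0.08 log units; within the scatter), which places all three aryl groups on this aromatic nitrogen within the scatter of one another. No measured property of these groups accompanies the result.

From the compounds shown here alone, all three groups are phenyl rings with no hydrogen-bond donors or acceptors, so it remains open whether an amine or a carboxylic acid on this ring would move the number beyond the scatter. The same question stands for a saturated ring such as cyclohexyl in place of the phenyl.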